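From 2-cyanobenzyl to methylsulfonyl on the amine nitrogen

The compounds below may be only part of what the source reports. "The series", "measured", "known", "first", "only" and "open" are said of these compounds alone.

In an ADME assay on MT4 cells (Homo sapiens) for cytotoxicity, read by MTT assay, with a stated time of 5 days (on this read-out lower numbers stand for higher toxicity in this test and higher numbers for lower toxicity in this test), compound 1 (`Cc1cc(C)cc(S(=O)(=O)c2c(C(=O)N[C@@H]3CCNC3)[nH]c3ccc(Cl)cc23)c1`) gives 37300 nM as a measured number. Compound 2 (`Cc1cc(C)cc(S(=O)(=O)c2c(C(=O)N[C@H]3CCN(Cc4ccccc4C#N)C3)[nH]c3ccc(Cl)cc23)c1`) gives > 228000 nM as a limit of the assay and not as a number. On these data alone, on these two readings, compound 2 stands on the side of lower toxicity in this test, and its true value remains unknown.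

Compound 3 (`Cc1cc(C)cc(S(=O)(=O)c2c(C(=O)N[C@H]3CCN(S(C)(=O)=O)C3)[nH]c3ccc(Cl)cc23)c1`) keeps the core of compound 2 and carries methylsulfonyl in place of 2-cyanobenzyl on an amine nitrogen in a ring. Within the data shown here, no measured step covers this change, so the expectation for this assay is a loose one. A moderate drop in the read-out is expected, toward higher toxicity in this test. Among the measured compounds shown here, the expectation rests on compound 1, whose 37300 nM is the only measured number and marks the lower region of the expected range. The estimate amounts to an expected at least 2.0-fold lower number from compound 2 to compound 3 (0.31 log units; beyond the scatter) in size. Compound 3 is estimated at 110000 nM in this assay, with an expected range from 30000 nM to 260000 nM for the coming measurement.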

Compound 3, half-maximal cytotoxic concentration: 29900 nM
Estimate against measurement, compound 3: 3.7-fold (0.57 log units) above, and the stated range ends above it.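

In this assay, methylsulfonyl in place of 2-cyanobenzyl on the amine nitrogen in a ring gives an at least 7.6-fold lower number from compound 2 to compound 3 (0.88 log units; beyond the scatter), which shows that the group on this nitrogen can move the read-out well beyond the scatter. Among these compounds, compound 3 and compound 1, which has no group on this nitrogen, cannot be told apart in this assay, with a 1.2-fold lower number from compound 1 to compound 3 (0.10 log units; within the scatter); among the three compounds, only the one with 2-cyanobenzyl reads apart from the others, so methylsulfonyl here does not carry over the reading of compound 2. The first step has only a lower bound on its size, and the true distance stays unknown, because compound 2 gives a limit of the assay and not a number: the limit of > 228000 nM in this assay, at which 1 of the 3 values shown sits.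

On these data alone, it remains open whether the reading of compound 2 goes with the benzyl ring or with the nitrile, which a plain benzyl group on the same nitrogen would separate. As far as these compounds go, it is also open whether an acetyl group or a longer alkyl chain at this place would read with compound 1 and compound 3 or with compound 2.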